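Aryl replacement in a growth-inhibition series: working notes

This account rests on a few compounds, and the source may have more. Where it says the series, first, only, none or still open, it means among the compounds named here.

Values measured in a functional assay on cells (Cancer cell lines, Homo sapiens) for cytotoxicity, read by sulforhodamine B assay, with a stated time of 48 h; on this read-out lower numbers stand for stronger inhibition of growth and higher numbers for weaker inhibition of growth:

compound 1 `COc1ccc(C2=NN(C3=NC(=O)/C(=C4\C(=O)Nc5ccc(Br)cc54)S3)C(c3ccc(OC)cc3)C2)cc1`: 32500 nM
compound 2 `COc1ccc(C2CC(c3ccc4ccccc4c3)=NN2C2=NC(=O)/C(=C3\C(=O)Nc4ccc(Br)cc43)S2)cc1`: 850 nM
compound 3 `COc1ccc(C2=NN(C3=NC(=O)/C(=C4\C(=O)Nc5ccccc54)S3)C(c3ccc(Cl)cc3)C2)cc1`: 100000 nM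

Compound 3 gives the highest of the three numbers in this assay. The difference between the core of compound 3 and the core of compound 1 is not broken down here.

Compound 4 `O=C1N=C(N2N=C(c3ccc4ccccc4c3)CC2c2ccc(Cl)cc2)S/C1=C1/C(=O)Nc2ccccc21` is not yet measured. It differs from compound 3 by naphthalen-2-yl in place of 4-methoxyphenyl on a carbon with a double bond to nitrogen. The same kind of change, (naphthalen-2-yl in place of 4-methoxyphenyl on a carbon with a double bond to nitrogen), is already measured once and gave a 38-fold lower number from compound 1 to compound 2 (1.58 log units; beyond the scatter). The surroundings are not identical: in compound 1 the ring atom two ring bonds from the changed carbon bears a 4-methoxyphenyl group (8 heavy atoms), while in compound 3 that atom bears a 4-chlorophenyl group (7 heavy atoms). The change is therefore the same kind of change, not the same.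

A step of comparable size is expected from compound 3 to compound 4 in this assay, namely a 33-fold lower number from compound 3 to compound 4 (1.52 log units; beyond the scatter), because the same kind of change gave a 38-fold lower number from compound 1 to compound 2 (1.58 log units; beyond the scatter). Among the compounds with values here, with only one prior example, the expectation is held loosely. Compound 4 is estimated at 3000 nM, expected between 700 nM and 20000 nM.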

Compound 4, concentration for total growth inhibition: 56100 nM
Estimate against measurement, compound 4: 19-fold (1.27 log units) below, outside the stated range (above it).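

In this assay, within the data shown here, the replacement of 4-methoxyphenyl by naphthalen-2-yl gives a 1.8-fold lower number from compound 3 to compound 4 (0.25 log units; within the scatter), so on this core the change leaves no step that can be told from the scatter. Set beside the earlier case, the same change does not carry over at a fixed size: the same change on two cores in this assay, a 38-fold lower number (1.58 log units; beyond the scatter) from compound 1 to compound 2 and a 1.8-fold lower number (0.25 log units; within the scatter) from compound 3 to compound 4, 21-fold (1.33 log units) apart, beyond the scatter of two such steps. Among these compounds, this shows that the large step seen on the core of compound 1 cannot be assumed on another core, but with only two pairs it does not show which difference between the cores matters, the bromine carried by compound 1 and compound 2 or the 4-chlorophenyl group carried by compound 3 and compound 4 in place of 4-methoxyphenyl.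

Still open, on these data alone, is whether a compound with the bromine and the 4-chlorophenyl group together would show the large step or the small one. Also open, as far as these compounds go, is how a morpholine or a carboxylic acid on the carbon with a double bond to nitrogen would read in this assay.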